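Capping the hydroxy group of compound 1 as methoxy

A few compounds are considered here, and "the series" means these few. Any claim that something is new, unique, unknown or untested is made for them only; others in the source may bear on it.

Measured in a functional assay on SK-MEL-2 cells (Homo sapiens) for antiproliferative activity, read by sulforhodamine B assay, with a stated time of 48 h; on this read-out higher numbers stand for weaker inhibition of growth and lower numbers for stronger inhibition of growth:
- compound 1 `O=C(NCCCNc1cc(-c2cn(-c3ccccc3)nc2-c2cccc(O)c2)ccn1)Nc1ccc(F)cc1`: 10100 nM
- compound 2 `O=C(NCCCNc1cc(-c2cn(-c3ccccc3)nc2-c2cccc(O)c2)ccn1)Nc1cccc(C(F)(F)F)c1`: 11700 nM

Going by the values given here, with only two numbers so far, compound 1 cannot be ranked against compound 2. The only measured move is a 1.2-fold higher number from compound 1 to compound 2 (0.06 log units; within the scatter), and it places 3-(trifluoromethyl)phenyl where 4-fluorophenyl stood on an amide-type nitrogen.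

The next compound is compound 3 `COc1cccc(-c2nn(-c3ccccc3)cc2-c2ccnc(NCCCNC(=O)Nc3ccc(F)cc3)c2)c1`, which keeps the core of compound 1 and changes one spot: methyl in place of hydrogen on an oxygen on an aromatic ring. This turns hydroxy into methoxy, and so 3-hydroxyphenyl into 3-methoxyphenyl.

Among the compounds with values here, no measured pair touches that hydroxy group, so the one known step bears on this change only weakly. It shows that a single edit elsewhere in the molecule stayed within the scatter in this assay. On that thin evidence, no step beyond the scatter is expected, and no direction can be favoured. The expected change is a 1.1-fold higher number from compound 1 to compound 3 (0.04 log units; within the scatter). For compound 3 the estimated value is 11000 nM, with an expected range from 5000 nM to 25000 nM.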

Compound 3, concentration for total growth inhibition: 12600 nM
Compound 3: middle estimate off by 1.1-fold (0.06 log units), on the low side; measured number inside the range.
By their numbers in this assay, from the lowest: compounds 1, 2 and 3 (each within the scatter of the next).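

In this assay, the change from hydroxy to methoxy gives a 1.2-fold higher number from compound 1 to compound 3 (0.10 log units; within the scatter) and so stays within the usual scatter. Going by these compounds alone, this is the first measured edit at this oxygen, as the earlier step changed only the aryl group on the urea end of the molecule. For this one pair, the hydrogen on the oxygen of the 3-hydroxyphenyl group can therefore be replaced by methyl with no readable change in the number, so a free hydroxy group is not required to keep the read-out at this level. Nothing measured here speaks to what lies behind this result.

A single small cap on one oxygen says little about larger changes at this spot, so an ethoxy group, a longer chain on the oxygen, or an amine or a carboxylic acid in place of the hydroxy group could still behave differently. As far as these compounds go, it also remains open whether methoxy would read the same alongside the 3-(trifluoromethyl)phenyl group of compound 2, and which part of the molecule, if any, can move this number beyond the scatter.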